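A few compounds are considered here, and "the series" means these few. Any claim that something is new, unique, unknown or untested is made for them only; others in the source may bear on it.

Measured compounds in an assay on isolated protein with Bile acid receptor (Homo sapiens) as the target; a higher number here means that more compound is needed for the effect, a lower number that less compound is needed:
- compound 1 `COC(=O)/C=C/c1cccc(N(Cc2ccc(-c3ccc(F)c(Cl)c3)cc2)C(=O)C2CCCCC2)c1` gives 66 nM
- compound 2 `COC(=O)/C=C/c1cccc(N(Cc2ccc(-c3c(OC)cccc3OC)cc2)C(=O)C2CCCCC2)c1` gives 77 nM
- compound 3 `COC(=O)/C=C/c1cccc(N(Cc2ccc(Br)cc2)C(=O)C2CCCCC2)c1` is reported only as a limit, > 1000 nM; this is a limit of this assay, not a number

Compound 3 therefore stands at the weak end of the three, with no exact value: its step from compound 1 is an at least 15-fold higher number from compound 1 to compound 3 (1.18 log units; beyond the scatter) and from compound 2 it is an at least 12-fold higher number from compound 2 to compound 3 (1.11 log units; beyond the scatter), both large, whereas compound 1 and compound 2 lie within the scatter of each other a 1.2-fold higher number from compound 1 to compound 2 (0.07 log units; within the scatter). Within the data shown here, the one limit among the three values the limit of > 1000 nM in this assay, at which 1 of the 3 values shown sits, is the one for compound 3.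

Compound 4 `COC(=O)/C=C/c1cccc(N(Cc2ccc(-c3cccc(C(C)=O)c3)cc2)C(=O)C2CCCCC2)c1` differs from compound 3 by 3-acetylphenyl in place of bromo on an aromatic carbon. This reverses the kind of change seen in the two large steps to compound 3, replacing bromo with an aryl group as in compound 1 and compound 2. The expectation is a large drop in number, an at least 12-fold lower number from compound 3 to compound 4 (1.09 log units; beyond the scatter), back toward the range of compound 1 and compound 2. Compound 4 is estimated at 80 nM, within 30 nM to 250 nM.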

Compound 4, half-maximal effective concentration: 227 nM
Estimate against measurement, compound 4: 2.8-fold (0.45 log units) below, and the stated range covers the measured number.
By their numbers in this assay, from the lowest: compounds 1 and 2 (each within the scatter of the next); then compound 4. At a limit, above all of these: compound 3.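

In this assay, 3-acetylphenyl in place of bromo also lowers the number, an at least 4.4-fold lower number from compound 3 to compound 4 (0.64 log units; beyond the scatter), so the drop from the bromo compound is not confined to the two aryl groups of compound 1 and compound 2. Compound 3 remains a limit and not a number: the limit of > 1000 nM in this assay, at which 1 of the 4 values shown sits. The aryl groups are not interchangeable at this position, a difference that compound 1 and compound 2, within the scatter of each other, did not reveal: the 3-acetylphenyl group gives a 2.9-fold higher number from compound 2 to compound 4 (0.47 log units; beyond the scatter) and a 3.4-fold higher number from compound 1 to compound 4 (0.54 log units; beyond the scatter).

On these data alone, it remains open whether the acetyl group itself or its place on the outer ring sets this higher number. Also open, as far as these compounds go, is whether an aromatic ring is needed here at all, or whether a morpholine, a carboxylic acid or a longer alkyl chain could take the place of bromo with a similar drop.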